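Removing the chloro: from compound 3 to compound 4

The source may report more compounds than this note shows. Statements on the series, on what has been measured and on what is new or still open speak of the compounds shown alone.

Measured so far:
compound 1, `COc1ccc(/C=N/Cc2cccnc2)cc1O`, 30 mg/kg
compound 2, `O=[N+]([O-])c1ccc(/C=N/Cc2cccnc2)cc1`, 100 mg/kg
compound 3, `Clc1ccccc1/C=N/Cc1cccnc1`, 30 mg/kg

In a functional assay on the whole organism (strain Swiss albino) with Mus musculus as the target, in the maximal electroshock model, with a stated time of 0.5 h (a higher number here means that more compound is needed for the effect, a lower number that less compound is needed), compound 3 gives 30 mg/kg. Among the compounds with values here, that number is level with the one for compound 1, and the two together stand lowest of the three; compound 2 gives 100 mg/kg, a number higher than that of compound 3 by a margin beyond the scatter. Within the data shown here, no pair of these three compounds differs in one place only, so no single step between measured compounds can be read.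

Compound 4, `C(=N/Cc1cccnc1)\c1ccccc1`, has not yet been measured in this assay. It differs from compound 3 by hydrogen in place of chloro on an aromatic carbon. Among the measured compounds shown here, there is no measured step that shows how such a change moves the number; the three measured compounds only show that different groups on the six-membered aromatic ring of carbon only leave the number within a modest span. Compound 4 is therefore expected to stay close to compound 3, with a step of no change at the digits printed from compound 3 to compound 4 (within the scatter) that is estimated to lie within the scatter, in either direction. The estimate for compound 4 is 30 mg/kg, with a range from 10 mg/kg to 100 mg/kg.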

Compound 4, minimum effective dose: 100 mg/kg
For compound 4 the middle estimate is 3.3-fold (0.52 log units) below the measured one; low and high end bracket the measured number.
By their numbers in this assay, from the lowest: compounds 1 and 3 (each within the scatter of the next); then compounds 2 and 4 (each within the scatter of the next).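

In this assay, within the data shown here, the chloro on an aromatic carbon, ortho to a group of 9 heavy atoms, is the first group whose replacement can be read on its own: hydrogen in its place gives a 3.3-fold higher number from compound 3 to compound 4 (0.52 log units; beyond the scatter), so this position does not tolerate every substituent equally. Hydrogen in place of nitro gives no change at the digits printed from compound 2 to compound 4 (within the scatter), so of these two single changes only the loss of chloro moves the number beyond the scatter. Nothing measured here bears on why the chloro matters.

From the compounds shown here alone, whether fluoro, bromo or an amine on this same carbon would keep the number of compound 3 stays open. So does whether chloro elsewhere on the six-membered aromatic ring of carbon only would do the same.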